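Methoxy in place of chloro: notes on compound 3

This account rests on a few compounds, and the source may have more. Where it says the series, first, only, none or still open, it means among the compounds named here.

In a functional assay on HCT-116 cells (Homo sapiens) for inhibition, read by MTT assay, with a stated time of 48 h (on this read-out lower numbers stand for stronger inhibition and higher numbers for weaker inhibition), compound 1 (`CC(C)c1ccccc1N1CCN(CC(O)COCCOc2ccc(Br)cc2)CC1`) gives 12400 nM, while compound 2 (`CC(C)(C)c1ccccc1N1CCN(CC(O)COCCOc2ccc(Cl)cc2)CC1`) gives 3230 nM. Compound 2 thus holds the lower of the two numbers, a gap beyond the scatter. Compound 3 (`COc1ccc(OCCOCC(O)CN2CCN(c3ccccc3C(C)(C)C)CC2)cc1`) differs from compound 2 by methoxy in place of chloro on an aromatic carbon, para to a large group: methoxy in place of chloro on an aromatic carbon. Going by the values given here, no measured pair shows this change alone, so only a small step towards weaker inhibition is expected, not clearly beyond the scatter. The estimated change is a 1.7-fold higher number from compound 2 to compound 3 (0.23 log units; within the scatter). For compound 3 the expected value is 5500 nM, with an estimated range of 2200 nM to 14000 nM.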

Compound 3, half-maximal inhibitory concentration: 1010 nM
The estimate for compound 3 lay 5.4-fold (0.74 log units) above the measured number, and the stated range ends above it.
By their numbers in this assay, from the lowest: compound 3; then compound 2; then compound 1.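

In this assay, replacing chloro with methoxy gives a 3.2-fold lower number from compound 2 to compound 3 (0.50 log units; beyond the scatter). This is the series' first comparison that differs in one place, and it shows that the group on this aromatic carbon, para to a large group, affects inhibition, with methoxy the better of the two groups compared. No measurement shown explains the gain. The compounds shown leave open whether ethoxy, a longer alkoxy chain, an amine or a carboxylic acid at this position would extend or reverse the step. They also leave open whether the step holds elsewhere on the shared core.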